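The source may hold more compounds than are shown below. What is called first, only, known or untested is meant among the compounds shown, and "the series" means these compounds.

Measured so far in a functional assay on PC-3M cells (Homo sapiens) for antiproliferative activity, read by microscopy, with a stated time of 24 h; a lower number here means a stronger inhibitor, a higher number a weaker inhibitor:
compound 1 `OCCCNc1ncnc2c1c(-c1ccccc1)c(-c1ccccc1)n2Cc1ccccc1` returns a limit of this assay, > 20000 nM, and no number.
compound 2 `N=c1c2c(-c3ccccc3)c(-c3ccccc3)n(Cc3ccccc3)c2ncn1CCNc1ccncc1` gives 6590 nM; 6610 nM (2 entries).
compound 3 `N=c1c2c(-c3ccccc3)c(-c3ccccc3)n(CC3CC3)c2ncn1C1CCOCC1` gives 830 nM; 832 nM (2 entries).

Compound 1 is the only one of the three without a single number: its entry is a limit, the point marked by the limit of > 20000 nM in this assay, at which 1 of the 3 values shown sits. Going by the values given here, compounds 2 and 3 share neither the core nor the substitution pattern of compound 1, so they are not single-change neighbours of it; their repeated entries, the several entries of compound 2 in this assay, 6590 nM; 6610 nM (2 entries) and (the several entries of compound 3 in this assay, 830 nM; 832 nM (2 entries)), show only that compound 3 sits at a stronger number than compound 2 in this assay.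

Compound 4 `O[C@H]1CC[C@H](Nc2ncnc3c2c(-c2ccccc2)c(-c2ccccc2)n3Cc2ccccc2)CC1` differs from compound 1 by 4-hydroxycyclohexyl in place of 3-hydroxypropyl on a nitrogen on an aromatic ring. The hydroxyl and the amine are kept; the open chain becomes a saturated carbocycle with two defined stereocentres. Among the compounds with values here, no measured step of this kind stands, and the starting point is a limit rather than a number, so the size of the step cannot be anchored. The expectation is a modest gain in this assay, an at least 1.3-fold lower number from compound 1 to compound 4 (0.12 log units; that floor lies within the scatter), with wide uncertainty and a real chance that compound 4 again returns only a limit. On that basis compound 4 is estimated at 15000 nM, between 3000 nM and 60000 nM.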

Compound 4, half-maximal inhibitory concentration: > 20000 nM
Compound 4 gave a limit, no number; the forecaster's own chance of this, stated with the estimate: 50%; middle value at least 1.3-fold (0.12 log units) from the limit.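

Compound 1 and compound 4 each return only a limit in this assay, and the step from 3-hydroxypropyl to 4-hydroxycyclohexyl between them cannot be read: the limit of > 20000 nM in this assay, at which 2 of the 4 values shown sit.

The compounds shown leave open whether 4-hydroxycyclohexyl and 3-hydroxypropyl on that nitrogen differ at all in this assay.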